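A few compounds are considered here, and "the series" means these few. Any claim that something is new, unique, unknown or untested is made for them only; others in the source may bear on it.

Working notes on the series. In an ADME assay on Raji cells (Homo sapiens) for cytotoxicity, read by CellTiter-Glo and resazurin assay, with a stated time of 72 h (on this read-out lower numbers stand for an effect already at smaller amounts and higher numbers for an effect only at larger amounts of compound), compound 1 `COc1cc(F)cc(-c2ccc(C(=O)N(Cc3cccc(OCCCCCC(=O)O)c3)C(C)C)cc2)c1` gives > 26000 nM, which is a limit of the assay and not a number. Compound 2 `CCOC(=O)CCCCCOc1cccc(CN(C(=O)c2ccc(-c3ccc(C(C)=O)s3)cc2)C(C)C)c1` likewise gives only a limit in this assay, > 26000 nM. Compound 2 therefore stands where everything measured so far stands, at the limit of > 26000 nM in this assay, at which 2 of the 2 values shown sit; no numerical value is available for either compound.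

Compound 3 `CCOC(=O)CCCCCOc1cccc(CN(C(=O)c2ccc(-c3cccc([N+](=O)[O-])c3)cc2)C(C)C)c1` has not yet been measured in this assay. It differs from compound 2 in one place: 3-nitrophenyl in place of 5-acetylthiophen-2-yl on an aromatic carbon. Within the data shown here, no step between two measured compounds is at hand, so nothing shows how a change of this kind moves this read-out. With both measured compounds sitting at the limit, no step beyond the scatter in either direction is expected, and the most likely outcome is that compound 3 again returns a limit. The expected step is a step that the limit leaves unreadable from compound 2 to compound 3. Compound 3 is estimated at 30000 nM, within 10000 nM to 90000 nM.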

Compound 3, half-maximal effective concentration: > 26000 nM
Compound 3: only a limit was reported; the forecaster's own chance of this, stated with the estimate: 80%; the middle value does not contradict the limit.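

In this assay compound 2 and compound 3 both return only limits of the assay, so no step can be read from compound 2 to compound 3. The compounds shown leave open at what concentration any of them would have an effect in this assay: the limit of > 26000 nM in this assay, at which 3 of the 3 values shown sit.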